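The source may report more compounds than this note shows. Statements on the series, on what has been measured and on what is new or still open speak of the compounds shown alone.

In a functional assay on MCF7 cells (Homo sapiens) for cytotoxicity, read by MTT assay, with a stated time of 4 h (a higher number here means a weaker inhibitor, a lower number a stronger inhibitor), compound 1 (`COC(=O)C1=CO[C@@H](O[C@@H]2O[C@H](COC(c3ccccc3)(c3ccccc3)c3ccccc3)[C@@H](O)[C@H](O)[C@H]2O)[C@@H]2[C@@H](C)[C@@H](O)C[C@H]12`) gives 1 ug/mL and compound 2 (`COC(=O)C1=CO[C@@H](O[C@@H]2O[C@H](COC(c3ccccc3)(c3ccccc3)c3ccccc3)[C@@H](OC(=O)O)[C@H](OC(C)=O)[C@H]2OC(C)=O)[C@@H]2[C@@H](C)[C@@H](OC(C)=O)C[C@H]12`) gives 1.2 ug/mL, two values within the usual scatter of each other. Compound 3 (`COC(=O)C1=CO[C@@H](O[C@@H]2O[C@H](CO)[C@@H](OC(C)=O)[C@H](OC(C)=O)[C@H]2OC(C)=O)[C@@H]2[C@@H](C)[C@@H](OC(C)=O)C[C@H]12`) stands apart: it is reported as "not active" (no number reported), with no number, so it has no place on the scale beside them. The next structure is compound 4 (`CCC(=O)OC[C@H]1O[C@@H](O[C@@H]2OC=C(C(=O)OC)[C@H]3C[C@H](OC(C)=O)[C@H](C)[C@@H]23)[C@H](OC(C)=O)[C@@H](OC(C)=O)[C@@H]1OC(C)=O`). The change is propanoyl in place of hydrogen on an oxygen on a saturated carbon. Among the measured compounds shown here, no measured pair shows this change, so its effect can only be expected. Because compound 3 is "not active" (no number reported), no large gain in this assay is expected, and a weak result or none seems likely. The estimated value for compound 4 is 25 ug/mL, with an expected range of 4 ug/mL to 100 ug/mL.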

Compound 4, half-maximal inhibitory concentration: 1.88 ug/mL
For compound 4 the middle estimate is 13-fold (1.12 log units) above the measured one; measured number below the stated range.
By their numbers in this assay, from the lowest: compounds 1, 2 and 4 (each within the scatter of the next).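

In this assay compound 3 has no number, so the step from it to compound 4 cannot be read. Nothing measured here accounts for the result of compound 4. The compounds shown leave open how far the change from hydroxymethyl to (propanoyloxy)methyl alone moves the value.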